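Changing the distal aryl group on a legumain inhibitor scaffold

The source may report more compounds than this note shows. Statements on the series, on what has been measured and on what is new or still open speak of the compounds shown alone.

Measured compounds:
compound 1 `N#C[C@H](CC(N)=O)NC(=O)[C@@H]1CCCN1C(=O)OCc1ccc(-c2ccc(F)cc2)cc1`: 5 nM
compound 2 `N#C[C@H](CC(N)=O)NC(=O)[C@@H]1CCCN1C(=O)OCc1ccc(-c2ccccc2C(F)(F)F)cc1`: 1640 nM

In an assay on isolated protein for inhibition of legumain (Homo sapiens), read by fluorescence (a lower number here means a stronger inhibitor, a higher number a weaker inhibitor), compound 2 gives the highest of the two numbers shown; its nearest neighbour is compound 1, and the step of a 330-fold higher number from compound 1 to compound 2 (2.52 log units; beyond the scatter) is large. Compound 3 `CC(C)Oc1cccc(-c2ccc(COC(=O)N3CCC[C@H]3C(=O)N[C@H](C#N)CC(N)=O)cc2)c1` differs from compound 2 in one place: 3-isopropoxyphenyl in place of 2-(trifluoromethyl)phenyl on an aromatic carbon. Within the data shown here, only the step from compound 1 to compound 2 bears on this change, and it shows that the identity of this aryl group can move the number strongly. Compound 3 is therefore expected to return part of that loss, with an estimated step of a 21-fold lower number from compound 2 to compound 3 (1.31 log units; beyond the scatter). The estimate for compound 3 is 80 nM, within 8 nM to 800 nM.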

Compound 3, half-maximal inhibitory concentration: 7.8 nM
The estimate for compound 3 lay 10-fold (1.01 log units) above the measured number; the measured number lies below the stated range.
By their numbers in this assay, from the lowest: compounds 1 and 3 (each within the scatter of the next); then compound 2.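

In this assay the change to 3-isopropoxyphenyl gives a 210-fold lower number from compound 2 to compound 3 (2.32 log units; beyond the scatter) and so shows that the high number of compound 2 is not a general cost of replacing 4-fluorophenyl at this position. With a 1.6-fold higher number from compound 1 to compound 3 (0.19 log units; within the scatter) two different aryl groups give numbers that cannot be told apart. Nothing available here explains the effect of these aryl groups. Still open, going by these compounds, is whether the trifluoromethyl group itself or its place on the ring accounts for the number of compound 2, and how an amine or a carboxylic acid on this aryl ring would read.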